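A few compounds are considered here, and "the series" means these few. Any claim that something is new, unique, unknown or untested is made for them only; others in the source may bear on it.

Among the compounds with values here, in a functional assay on SW-620 cells (Homo sapiens) for inhibition, read by MTT assay, with a stated time of 72 h (a lower number here means a stronger inhibitor of growth, a higher number a weaker inhibitor of growth), compound 1 `Cc1nn(C)cc1-c1nc2c(N3CCN(Cc4ncn(C)n4)CC3)c(Cl)cnc2[nH]1` gives 3140 nM as the lower of the two numbers so far, and compound 2 `Cc1cc(CN2CCN(c3c(Cl)cnc4[nH]c(-c5ccoc5)nc34)CC2)no1` gives 6500 nM as the higher, a gap beyond the usual scatter. Compound 3 `Cc1nn(C)cc1-c1nc2c(N3CCN(Cc4nonc4C)CC3)c(Cl)cnc2[nH]1` keeps the core of compound 1 and carries a single change (4-methyl-1,2,5-oxadiazol-3-yl in place of 1-methyl-1H-1,2,4-triazol-3-yl on a saturated chain carbon bound to an amine nitrogen in a ring) that puts 4-methyl-1,2,5-oxadiazol-3-yl in place of 1-methyl-1H-1,2,4-triazol-3-yl on a saturated chain carbon bound to an amine nitrogen in a ring. Within the data shown here, no measured pair shows this change, so the expectation in this assay rests on the structural change alone, and no step beyond the scatter is expected in either direction. The estimated step is a 1.1-fold higher number from compound 1 to compound 3 (0.05 log units; within the scatter) and is expected to stay inside the scatter. For compound 3 the estimate is 3500 nM with an expected range from 1500 nM to 8000 nM until the measurement is in.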

Compound 3, concentration for 50% growth inhibition: 250 nM
Compound 3: the middle estimate sits 14-fold (1.15 log units) above what was measured; the measured number lies below the stated range.
By their numbers in this assay, from the lowest: compound 3; then compound 1; then compound 2.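

In this assay, within the data shown here, the group on a saturated chain carbon bound to an amine nitrogen in a ring proves to be a sensitive point: 4-methyl-1,2,5-oxadiazol-3-yl in place of 1-methyl-1H-1,2,4-triazol-3-yl gives a 13-fold lower number from compound 1 to compound 3 (1.10 log units; beyond the scatter), the only single-change step available. The two groups have the same counts of heavy atoms, hydrogen-bond donors and acceptors, and neither carries a net charge, so these counts do not separate them. Among these compounds, nothing measured so far accounts for the step.

Among the compounds shown here, only one pair carries this change, so it remains open whether the step holds on another core. Also open, as far as these compounds go, is how the same place responds to the ring without its methyl group, or to a phenyl ring or a dimethylamino group.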